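Benzyl-thioether variation on the shared core: towards a naphthyl analogue

The source may report more compounds than this note shows. Statements on the series, on what has been measured and on what is new or still open speak of the compounds shown alone.

Compound 1 `Cc1cc(Nc2cc(-c3ccccc3)[nH]n2)n2nc(SCc3ccc([N+](=O)[O-])cc3)nc2n1` carries a 4-nitrobenzyl group on the sulfur of the shared core. In a functional assay on MCF7 cells (Homo sapiens) for inhibition, read by MTT assay, with a stated time of 72 h (on this read-out lower numbers stand for stronger inhibition and higher numbers for weaker inhibition), compound 1 gives 5060 nM. Compound 2 `Cc1ccc(CSc2nc3nc(C)cc(Nc4cc(-c5ccccc5)[nH]n4)n3n2)cc1` gives 7290 nM, and compound 3 `Cc1cc(Nc2cc(-c3ccccc3)[nH]n2)n2nc(SCc3ccc(C(F)(F)F)cc3)nc2n1` gives 4820 nM. Compound 1 thus stands second highest of the three numbers, nearest compound 3 and furthest from compound 2, with all three values within the scatter of one another. The steps of a 1.4-fold higher number from compound 1 to compound 2 (0.16 log units; within the scatter), a 1.0-fold lower number from compound 1 to compound 3 (0.02 log units; within the scatter) and a 1.5-fold lower number from compound 2 to compound 3 (0.18 log units; within the scatter) all stay within the scatter: exchanging the group on the aromatic carbon has not moved the number.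

Compound 4 `Cc1cc(Nc2cc(-c3ccccc3)[nH]n2)n2nc(SCc3cccc4ccccc34)nc2n1` changes this position more deeply: naphthalen-1-yl in place of 4-nitrophenyl on a saturated chain carbon bound to a sulfur. Among the measured compounds shown here, no measured step covers an exchange of this kind, so the only guidance is that the three measured steps on the same phenyl ring were all flat. On that basis the step of a 1.0-fold lower number from compound 1 to compound 4 (0.01 log units; within the scatter) is expected to be small, with no direction preferred beyond the scatter. For compound 4 the estimate is 5000 nM, expected to fall between 2000 nM and 13000 nM.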

Compound 4, half-maximal inhibitory concentration: 7560 nM
Estimate against measurement, compound 4: 1.5-fold (0.18 log units) below; low and high end bracket the measured number.
By their numbers in this assay, from the lowest: compounds 3, 1, 2 and 4 (each within the scatter of the next).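

In this assay, the change from a single substituted phenyl to naphthalen-1-yl on a saturated chain carbon bound to a sulfur leaves the number flat: a 1.5-fold higher number from compound 1 to compound 4 (0.17 log units; within the scatter), a 1.6-fold higher number from compound 3 to compound 4 (0.20 log units; within the scatter) and a 1.0-fold higher number from compound 2 to compound 4 (0.02 log units; within the scatter). Among the compounds shown here, the earlier compounds showed only that the group on the phenyl ring could be exchanged without a step beyond the scatter; compounds 1, 2, 3 and 4 now show the same for a second fused aromatic ring, and the 4-nitrobenzyl to (naphthalen-1-yl)methyl change separates nothing here. No available measurement accounts for this flatness.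

From the compounds shown here alone, all four compounds keep an aromatic group on this carbon, so the effect of an amine, a carboxylic acid or a longer chain there remains open. Going by these compounds, whether naphthalen-2-yl reads like naphthalen-1-yl also remains open.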